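The source may report more compounds than this note shows. Statements on the series, on what has been measured and on what is new or still open speak of the compounds shown alone.

Compounds measured:
compound 1, `COc1cc(N)c(Cl)cc1C(=O)CCC1CCN(CCNS(=O)(=O)c2cc(Br)ccc2Br)CC1`, with 52%;
compound 2, `COc1ccc(S(=O)(=O)NCCN2CCC(CCC(=O)c3cc(Cl)c(N)cc3OC)CC2)cc1Cl`, with 85%;
compound 3, `COc1cc(N)c(Cl)cc1C(=O)CCC1CCN(CCNS(=O)(=O)c2ccc(C)cc2)CC1`, with 15%.

In an assay on HEK293 cells for displacement of a labelled ligand from 5-hydroxytryptamine receptor 6 (Homo sapiens), with a stated time of 60 min, tested at 1 uM, in the presence of a further agent that is not named here (a higher number here means a stronger effect of the compound at the concentration tested, a lower number a weaker effect), compound 3 stands lowest of the three; compound 1 is nearest and compound 2 furthest. Compound 4, `COc1cc(N)c(Cl)cc1C(=O)CCC1CCN(CCNS(=O)(=O)c2ccc(N)c(Br)c2)CC1`, differs from compound 3 by 4-amino-3-bromophenyl in place of 4-methylphenyl on a sulfonyl sulfur. Within the data shown here, two measured steps bear on this change, both of them exchanges of the aryl group on the sulfonyl sulfur: a number 37 percentage points lower from compound 1 to compound 3 (beyond the scatter) and a number 70 percentage points lower from compound 2 to compound 3 (beyond the scatter). In each case the 4-methylphenyl compound gives the weaker result, and the halogen-bearing aryl groups give the stronger. Because of a number 37 percentage points lower from compound 1 to compound 3 (beyond the scatter), a bromine-bearing aryl replacing 4-methylphenyl is expected to raise the number in this assay by a large step. Compound 4 is therefore estimated at 50%, within 25% to 75%, an expected step of a number 35 percentage points higher from compound 3 to compound 4 (beyond the scatter).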

Compound 4, a percentage reported as inhibition, at one concentration (the size of the read-out at that concentration, not a potency): 85%
For compound 4 the middle estimate is 35 percentage points below the measured one; the whole stated range lies below it.
By their numbers in this assay, from the lowest: compound 3; then compound 1; then compounds 2 and 4 (each within the scatter of the next).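

In this assay, 4-amino-3-bromophenyl in place of 4-methylphenyl on the sulfonyl sulfur gives a number 70 percentage points higher from compound 3 to compound 4 (beyond the scatter), the same size of step as that seen with 3-chloro-4-methoxyphenyl. Against that group the new aryl gives no change at the digits printed from compound 2 to compound 4 (within the scatter), whereas against 2,5-dibromophenyl it gives a number 33 percentage points higher from compound 1 to compound 4 (beyond the scatter), so carrying bromine does not by itself set the number at this position. Nothing measured here accounts for these differences. From the compounds shown here alone, it remains open how a 4-aminophenyl or a 3-bromophenyl group on the sulfonyl sulfur would read, and so whether the amine or the bromine carries the step.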